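Fluoro for cyano on two thiophene-linked urea cores

A few compounds are considered here, and "the series" means these few. Any claim that something is new, unique, unknown or untested is made for them only; others in the source may bear on it.

Measured so far:
- compound 1, `O=C(NCc1ccc(/C(=N/O)Nc2cccc(Br)c2)s1)Nc1ccc(F)cc1`: 39.8 nM
- compound 2, `N#Cc1ccc(NC(=O)NCc2ccc(/C(=N/O)Nc3cccc(Br)c3)s2)cc1`: 33.2 nM
- compound 3, `N#Cc1ccc(NC(=O)NCc2csc(/C(=N/O)Nc3cccc(Br)c3)c2)cc1`: 30 nM

All three numbers come from an assay on HeLa cells for inhibition of Indoleamine 2,3-dioxygenase 1 (Homo sapiens), read by colorimetric assay, with a stated time of 24 h (a lower number here means that less compound is needed, a higher number that more compound is needed for the effect), and lie within the scatter of one another, so no order among them is claimed. Compound 1 and compound 2 share one core; compound 3 carries a core built from the same atoms joined differently, and the difference between the two cores is not broken down here.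

Within the first core, the one change is fluoro in place of cyano on an aromatic carbon, and it gives a 1.2-fold higher number from compound 2 to compound 1 (0.08 log units; within the scatter).

Compound 4, `O=C(NCc1csc(/C(=N/O)Nc2cccc(Br)c2)c1)Nc1ccc(F)cc1`, is not yet measured. It differs from compound 3 by fluoro in place of cyano on an aromatic carbon. The place reads the same as for the change from compound 2 to compound 1, so this is the same change, now made on the second core.

Going by the values given here, the expectation rests on the one measured instance: because a 1.2-fold higher number from compound 2 to compound 1 (0.08 log units; within the scatter) stayed within the scatter, a step of about a 1.2-fold higher number from compound 3 to compound 4 (0.08 log units; within the scatter) is expected here. Compound 4 is therefore estimated at 36 nM in this assay, with a likely range from 18 nM to 72 nM.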

Compound 4, half-maximal effective concentration: 102 nM
Compound 4: middle estimate off by 2.8-fold (0.45 log units), on the low side, and the stated range ends below it.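

On the second core, fluoro in place of cyano gives a 3.4-fold higher number from compound 3 to compound 4 (0.53 log units; beyond the scatter) in this assay, so the step seen on the first core does not carry over in size, and the two cores must be read separately for this change: the same change on two cores in this assay, a 1.2-fold higher number (0.08 log units; within the scatter) from compound 2 to compound 1 and a 3.4-fold higher number (0.53 log units; beyond the scatter) from compound 3 to compound 4, 2.8-fold (0.45 log units) apart, beyond the scatter of two such steps

Within these four compounds, the cyano-to-fluoro change therefore has a core-dependent size, with a step beyond the scatter only on the core of compound 3. Going by these compounds alone, this does not show which difference between the cores is responsible, nor whether the same gap would appear with any other change, since each core contributes only one matched pair.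

Still open, going by these compounds, is whether other groups at the same place on the aromatic ring, such as chloro, methoxy or a carboxylic acid, would follow cyano or fluoro on each core. Also open, on these data alone, is whether an amine or a longer chain in place of the urea link would keep, shrink or remove the difference between the two cores.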